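The source may report more compounds than this note shows. Statements on the series, on what has been measured and on what is new or still open speak of the compounds shown alone.

Measured so far:
compound 1 `CN(Cc1cccs1)C1CCN(CCCc2c[nH]c3ccc(-n4cnnc4)cc23)CC1` gives 4.3 nM in an assay on CHO cells for displacement of a labelled ligand from 5-hydroxytryptamine receptor 1D (Homo sapiens); on this read-out lower numbers stand for stronger inhibition and higher numbers for weaker inhibition;
compound 2 `O[C@@H]1Cc2ccccc2[C@H]1NC1CCN(CCCc2c[nH]c3ccc(-n4cnnc4)cc23)CC1` gives 6.6 nM in this assay.

Among the compounds with values here, compound 2 has the highest of the two numbers, but its only neighbour is compound 1, and the step of a 1.5-fold higher number from compound 1 to compound 2 (0.19 log units; within the scatter) lies within the scatter, so the two compounds cannot be ranked against each other.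

Compound 3 `c1ccc2c(c1)CCC2NC1CCN(CCCc2c[nH]c3ccc(-n4cnnc4)cc23)CC1` is the next analogue. It differs from compound 2 only in the amine substituent: 2,3-dihydro-1H-inden-1-yl in place of 2-hydroxy-2,3-dihydro-1H-inden-1-yl on an amine nitrogen. Within the data shown here, no measured step concerns this part of the molecule; the one step available, a 1.5-fold higher number from compound 1 to compound 2 (0.19 log units; within the scatter), exchanges the whole amine substituent and was itself within the scatter. The hydroxyl is thus untested in this series, and its loss is expected to give a step of a 1.4-fold higher number from compound 2 to compound 3 (0.13 log units; within the scatter), at most a modest one towards a higher number.

For compound 3 the expected value in this assay is 9 nM, with a range of 3 nM to 30 nM.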

Compound 3, half-maximal inhibitory concentration: 8.9 nM
Beside the measured number, compound 3's estimate is 1.0-fold (0.00 log units) above it, within the range that was stated.
By their numbers in this assay, from the lowest: compounds 1, 2 and 3 (each within the scatter of the next, the first and the last beyond it).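

In this assay, loss of the hydroxyl on the 2,3-dihydro-1H-inden-1-yl group gives a step that stays within the scatter (a 1.3-fold higher number from compound 2 to compound 3 (0.13 log units; within the scatter)), so these compounds show no measurable need for that hydroxyl at this amine nitrogen. Compared with the methyl((thiophen-2-yl)methyl)amino group, however, the (2,3-dihydro-1H-inden-1-yl)amino group gives the series' first separation beyond the scatter, though a modest one (a 2.1-fold higher number from compound 1 to compound 3 (0.32 log units; beyond the scatter)). Nothing at hand explains either step.

On these data alone, it remains open whether a methoxy or amino group in place of the hydroxyl would give a different reading, or whether a benzyl group would do so in place of the whole 2,3-dihydro-1H-inden-1-yl group. The contribution of the stereocentres defined in compound 2 also remains unresolved.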